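Swapping a Para Halogen for Methyl on a Weak Inhibitor

A few compounds are considered here, and "the series" means these few. Any claim that something is new, unique, unknown or untested is made for them only; others in the source may bear on it.

Compound 1 `CN(C)C/C=C(/c1ccc(Cl)cc1)c1cccnc1` gives 10000 nM in a functional assay on brain for inhibition of Norepinephrine transporter (Rattus norvegicus); a higher number here means a weaker inhibitor, a lower number a stronger inhibitor.
Compound 2 `CCCNC/C=C(/c1ccc(Br)cc1)c1cccnc1` gives > 24000 nM in this assay, which is a limit of the assay and not a number.
Compound 3 `CN(C)C/C=C(/c1ccc(I)cc1)c1cccnc1` gives > 22000 nM in this assay, again a limit and not a number.

Compound 3 therefore stands at a limit, and of the three values shown it is one of two that are limits rather than numbers, as noted in the limit of > 22000 nM in this assay, at which 1 of the 3 values shown sits, and (the limit of > 24000 nM in this assay, at which 1 of the 3 values shown sits); only compound 1 has a numeric value. The step from compound 1 to compound 3 is an at least 2.2-fold higher number from compound 1 to compound 3 (0.34 log units; beyond the scatter), a change of one halogen for another on the aromatic carbon.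

Compound 4 `Cc1ccc(/C(=C/CN(C)C)c2cccnc2)cc1` differs from compound 3 by methyl in place of iodo on an aromatic carbon. Among the measured compounds shown here, the only measured step that bears on this position is the one from compound 1 to compound 3, and it moved the number at least modestly. Nothing measured here shows how a methyl group at this position behaves. A step of modest size in either direction in this assay is plausible, so the expected change from compound 3 to compound 4 is estimated as an at least 1.8-fold lower number from compound 3 to compound 4 (0.26 log units; that floor lies within the scatter). Compound 4 is expected to give about 12000 nM in this assay, with a likely range from 3000 nM to 40000 nM.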

Compound 4, half-maximal inhibitory concentration: > 29000 nM
Compound 4 gave a limit, no number (the forecaster's own chance of this, stated with the estimate: 40%); middle value at least 2.4-fold (0.38 log units) from the limit.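

Methyl in place of chloro on this aromatic carbon weakens inhibition in this assay (an at least 2.9-fold higher number from compound 1 to compound 4 (0.46 log units; beyond the scatter)). Among the compounds shown here, both replacements of chloro with a measurable step, iodo in compound 3 and methyl in compound 4, therefore move the number the same way, although iodine and carbon are different atoms, and compound 1 remains the only one of the four compounds with a numeric value. The step between compound 3 and compound 4 cannot be read, so this comparison does not rank iodo against methyl, as each compound stands at a limit and not a number: the limit of > 22000 nM in this assay, at which 1 of the 4 values shown sits, and (the limit of > 29000 nM in this assay, at which 1 of the 4 values shown sits).

Going by these compounds, whether any other group on this aromatic carbon, such as fluoro, methoxy, an amine or a carboxylic acid, would give a lower number than compound 1 stays open. Also open, on these data alone, is how much weaker compound 3 and compound 4 are than compound 1, and whether a single group could restore inhibition on the shared core.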